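The compounds below may be only part of what the source reports. "The series", "measured", "known", "first", "only" and "open" are said of these compounds alone.

Within the data shown here, compound 2 `Cc1cc(C)c(NC(=O)N(Cc2cccc(-c3cc[nH]n3)c2)C2CCCCCC2)c(C)c1` in a functional assay on a cell-free system (plasma) with sterol O-acyltransferase, Soat (Rattus norvegicus) as the target (a lower number here means that less compound is needed, a higher number that more compound is needed for the effect), gives 0.097 mg/kg, the highest of two numbers so far; compound 1 `O=C(Nc1c(F)cc(F)cc1F)N(Cc1cccc(-c2cc[nH]n2)c1)C1CCCCCC1` gives 0.062 mg/kg, and the step of a 1.6-fold higher number from compound 1 to compound 2 (0.19 log units; within the scatter) lies within the scatter. Compound 3 `Cc1cc(C)c(NC(=O)N(Cc2cccc(-c3c[nH]cn3)c2)C2CCCCCC2)c(C)c1` is compound 2 with 1H-imidazol-4-yl in place of 1H-pyrazol-3-yl on an aromatic carbon. Among the measured compounds shown here, no measured step touches this change: the only measured step, a 1.6-fold higher number from compound 1 to compound 2 (0.19 log units; within the scatter), concerns the aryl group on the amide-type nitrogen and stays within the scatter. Compound 3 is therefore expected to show no step beyond the scatter a 1.0-fold higher number from compound 2 to compound 3 (0.01 log units; within the scatter). The expected value for compound 3 in this assay is 0.1 mg/kg, with a range from 0.04 mg/kg to 0.25 mg/kg.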

Compound 3, dose for half-maximal effect: < 1 mg/kg
Compound 3 was reported as a limit; the forecaster's own chance of this, stated with the estimate: 5%; the middle value lies beyond the limit too.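

Among these compounds, no step from compound 2 to compound 3 can be read, because compound 3 is reported only as a limit: the limit of < 1 mg/kg in this assay, at which 1 of the 3 values shown sits. As far as these compounds go, whether 1H-imidazol-4-yl in place of 1H-pyrazol-3-yl changes the number in this assay stays open.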